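The compounds below may be only part of what the source reports. "The series", "measured", "known", "first", "only" and "open" are said of these compounds alone.

Compound 1 `COc1ccccc1N1CCN(CCCNc2ncccc2C(=O)N(C)C)CC1`: 20 nM
Compound 2 `COc1ccccc1N1CCN(CCCNc2ncc(C#N)cc2C(=O)N(C)C)CC1`: 20 nM
Compound 3 `CN(C)C(=O)c1cccnc1NCCCN1CCN(c2ccccc2OCC(C)(C)C)CC1`: 50.1 nM

In a functional assay on aorta for antagonist activity at Alpha-1D adrenergic receptor (Rattus norvegicus) (on this read-out higher numbers stand for weaker binding and lower numbers for tighter binding), compound 3 gives the highest of the three numbers, separated from compound 1 by a 2.5-fold higher number from compound 1 to compound 3 (0.40 log units; beyond the scatter) and from compound 2 by the same margin. Compound 4 `CN(C)C(=O)c1cccnc1NCCCN1CCN(c2ccccc2C2CC2)CC1` differs from compound 3 in one place: cyclopropyl in place of neopentyloxy on an aromatic carbon. Going by the values given here, no measured step exchanges one ring substituent for another of a different kind, so the guidance is indirect. The step of a 2.5-fold higher number from compound 1 to compound 3 (0.40 log units; beyond the scatter) shows that enlarging the group on that aromatic carbon raised the number only modestly, while no change at the digits printed from compound 1 to compound 2 (within the scatter) elsewhere in the molecule changed nothing. Since compound 4 carries a group of fewer heavy atoms, a modest return toward the lower numbers is expected, estimated as a 2.0-fold lower number from compound 3 to compound 4 (0.30 log units; within the scatter). Compound 4 is therefore expected to give 25 nM, within 8 nM to 80 nM.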

Compound 4, dissociation constant: 63.1 nM
Beside the measured number, compound 4's estimate is 2.5-fold (0.40 log units) below it; the measured number falls inside the stated range.
By their numbers in this assay, from the lowest: compounds 1 and 2 (each within the scatter of the next); then compounds 3 and 4 (each within the scatter of the next).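

In this assay cyclopropyl in place of neopentyloxy gives a 1.3-fold higher number from compound 3 to compound 4 (0.10 log units; within the scatter) and so, on this aromatic carbon, a group with fewer heavy atoms and no oxygen does not separate from neopentyloxy. Cyclopropyl in place of methoxy gives a 3.2-fold higher number from compound 1 to compound 4 (0.50 log units; beyond the scatter) and so the move away from methoxy at this position can be made with or without an oxygen on the new group. Nothing at hand explains either step. As far as these compounds go, whether an ethoxy group, a chlorine atom or a hydroxyl group on that carbon would stay with compound 1 or with compound 3 remains open.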